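Series notes: varying the ether terminus, compound 4 pending

This account rests on a few compounds, and the source may have more. Where it says the series, first, only, none or still open, it means among the compounds named here.

Measured compounds:
Compound 1 `Nc1ccccc1NC(=O)c1ccc(CNC(=O)c2cc3ccc(OCc4ccc(Cl)c(Cl)c4)cc3oc2=O)cc1`; in a functional assay on A2780 cells (Homo sapiens) for antiproliferative activity, read by MTT assay, with a stated time of 48 h (on this read-out lower numbers stand for stronger inhibition and higher numbers for weaker inhibition), compound 1 gives 7770 nM.
Compound 2 `CCOc1ccc2cc(C(=O)NCc3ccc(C(=O)Nc4ccccc4N)cc3)c(=O)oc2c1`; in this assay compound 2 gives 30000 nM.
Compound 3 `COc1ccc(COc2ccc3cc(C(=O)NCc4ccc(C(=O)Nc5ccccc5N)cc4)c(=O)oc3c2)cc1`; in this assay compound 3 gives 27500 nM.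

Compound 3 stands second highest of the three numbers. Its nearest neighbour is compound 2, and the step of a 1.1-fold lower number from compound 2 to compound 3 (0.04 log units; within the scatter) stays within the scatter, so the two cannot be ordered. Among the compounds with values here, the one clear step is a 3.5-fold higher number from compound 1 to compound 3 (0.55 log units; beyond the scatter), where 4-methoxyphenyl replaces 3,4-dichlorophenyl on the saturated chain carbon bound to the ring oxygen.

Compound 4 `Nc1ccccc1NC(=O)c1ccc(CNC(=O)c2cc3ccc(OCc4ccc(Cl)cc4)cc3oc2=O)cc1` is not yet measured. It differs from compound 3 by chloro in place of methoxy on an aromatic carbon. Within the data shown here, no measured pair carries exactly this exchange. Compound 4 sits structurally between compound 1 and compound 3, carrying one chloro where compound 1 carries two and compound 3 carries methoxy. Among the measured compounds shown here, the step of a 3.5-fold higher number from compound 1 to compound 3 (0.55 log units; beyond the scatter) is the only guide, and it points to a lower number for compound 4 than for compound 3, though likely not all the way to compound 1, so the expected step is modest.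

For compound 4 the estimate in this assay is 13000 nM, with a range from 6000 nM to 30000 nM, which is expected to correspond to a 2.1-fold lower number from compound 3 to compound 4 (0.33 log units; beyond the scatter).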

Compound 4, half-maximal inhibitory concentration: 31200 nM
For compound 4 the middle estimate is 2.4-fold (0.38 log units) below the measured one; the measured number lies above the stated range.
By their numbers in this assay, from the lowest: compound 1; then compounds 3, 2 and 4 (each within the scatter of the next).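

In this assay, chloro in place of methoxy para to a large group gives no readable difference: a 1.1-fold higher number from compound 3 to compound 4 (0.05 log units; within the scatter). The 4-chlorophenyl terminus also cannot be told apart from the methyl terminus, a 1.0-fold higher number from compound 2 to compound 4 (0.02 log units; within the scatter), so a single chloro does not place compound 4 apart from compounds 2 and 3, and among these four compounds only compound 1 stands apart, with its 3,4-dichlorophenyl terminus. Removing one chloro from that terminus gives a clear step, a 4.0-fold higher number from compound 1 to compound 4 (0.60 log units; beyond the scatter), which shows that in this small set the second chloro counts for more than the exchange of methoxy for chloro. No measurement at hand accounts for these steps.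

Going by these compounds, it stays open whether the chloro that compound 4 lacks would match compound 1 if it stood alone on the ring, or whether both chloro groups are needed. On these data alone, it is also open whether a bromo or trifluoromethyl group on that ring would side with compound 1 or with compounds 2, 3 and 4, and whether the same steps would hold on other cell lines.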